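This account rests on a few compounds, and the source may have more. Where it says the series, first, only, none or still open, it means among the compounds named here.

In an ADME assay on microsomes from liver (Homo sapiens) for metabolic stability, read by LC-MS, using NADPH, with stated times of 10 min and 30 min (a lower number here means slower removal, a higher number faster removal of the compound), compound 1 `O=C1c2ccc(Cl)cc2CN1c1cccnc1` gives 12.8 mL/min/kg. Compound 2 `CCC1c2cc(Cl)ccc2C(=O)N1c1cccnc1` carries the change (ethyl in place of hydrogen on a saturated ring carbon), and in this assay compound 2 gives 6.6 mL/min/kg. The step is a 1.9-fold lower number from compound 1 to compound 2 (0.29 log units; within the scatter).

Compound 3 `CC(=O)N[C@@H]1CCCc2c1cncc2N1Cc2cc(Cl)ccc2C1=O` belongs to a different core; how its core differs from that of compound 1 is not broken down here. In this assay compound 3 gives < 3.5 mL/min/kg, and this is a limit of the assay, not a number, the point (the limit of < 3.5 mL/min/kg in this assay, at which 1 of the 3 values shown sits).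

Compound 4 `CC[C@H]1c2cc(Cl)ccc2C(=O)N1c1cncc2c1CCC[C@H]2NC(C)=O` is not yet measured. Within the data shown here, it carries the change (ethyl in place of hydrogen on a saturated ring carbon), the same kind of change as the one from compound 1 to compound 2, with a difference in the surroundings: in the earlier pair the neighbouring ring atom bears a pyridin-3-yl group (6 heavy atoms), here it bears a large group.

For compound 4 the expected step is a step that the limit leaves unreadable from compound 3 to compound 4, resting on the measured step of a 1.9-fold lower number from compound 1 to compound 2 (0.29 log units; within the scatter). The expectation also rests on the limit already reached by compound 3, which in this assay gives < 3.5 mL/min/kg. Compound 4 is therefore estimated at 3 mL/min/kg, between 1.5 mL/min/kg and 5 mL/min/kg, most likely again reported only as a limit.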

Compound 4, clearance: < 3.5 mL/min/kg
Compound 4: only a limit was reported (the forecaster's own chance of this, stated with the estimate: 70%); the middle value lies beyond the limit too.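

In this assay compound 4 gives < 3.5 mL/min/kg as a limit of the assay and not a number. Compound 3 also stands at a limit, so no step between compound 3 and compound 4 can be read: the limit of < 3.5 mL/min/kg in this assay, at which 2 of the 4 values shown sit.
On these data alone, what stays open is whether ethyl in place of hydrogen on a saturated ring carbon shifts clearance at all on this core, and by how much.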